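From Compound 2 to Compound 4: Furan-2-yl Replaces Pyridin-3-yl

A few compounds are considered here, and "the series" means these few. Any claim that something is new, unique, unknown or untested is made for them only; others in the source may bear on it.

Three analogues sharing one core have so far been run in an ADME assay on Vero cells (Chlorocebus sabaeus) for cytotoxicity; on this read-out higher numbers stand for lower toxicity in this test and lower numbers for higher toxicity in this test. Compound 1 `O=C(NCCO)c1cccc2[nH]c(-c3cccnc3)nc12` gives 682 uM. Compound 2 `O=C(Nc1ccccc1F)c1cccc2[nH]c(-c3cccnc3)nc12` gives 54.7 uM, and compound 3 `Cc1csc(NC(=O)c2cccc3[nH]c(-c4cccnc4)nc23)n1` gives 111 uM. Among these three numbers compound 2 stands lowest, with compound 3 nearest to it and compound 1 furthest away. Every measured step alters the group on the amide-type nitrogen: a 12-fold lower number from compound 1 to compound 2 (1.10 log units; beyond the scatter), a 6.1-fold lower number from compound 1 to compound 3 (0.79 log units; beyond the scatter) and a 2.0-fold higher number from compound 2 to compound 3 (0.31 log units; beyond the scatter).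

Compound 4 `O=C(Nc1ccccc1F)c1cccc2[nH]c(-c3ccco3)nc12` has not been measured. It differs from compound 2 at another place: furan-2-yl in place of pyridin-3-yl on an aromatic carbon. Going by the values given here, none of the measured steps touches this position, so none of them bears directly on the change; they show only that altering a group on the shared core can move the read-out beyond the scatter. Lacking a direct precedent, the expectation for compound 4 in this assay is a number near that of compound 2, with a step of a 1.1-fold higher number from compound 2 to compound 4 (0.04 log units; within the scatter) anticipated and no confident direction. Compound 4 is accordingly estimated at 60 uM, within a range from 20 uM to 180 uM.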

Compound 4, half-maximal toxic concentration: 25 uM
Estimate against measurement, compound 4: 2.4-fold (0.38 log units) above; measured number inside the range.
By their numbers in this assay, from the lowest: compound 4; then compound 2; then compound 3; then compound 1.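

The aromatic carbon between two ring nitrogen atoms turns out not to be a silent place in this assay: with the 2-fluorophenyl amide held constant, the change gives a 2.2-fold lower number from compound 2 to compound 4 (0.34 log units; beyond the scatter). Going by these compounds alone, until now, every step had altered the group on the amide-type nitrogen, so this is the first sign that the read-out also responds to the group at this second place on the shared core, and that the direction here is towards the lower number, meaning higher toxicity in this test. The swap exchanges a six-membered aromatic ring holding a nitrogen for a five-membered one holding an oxygen, while the counts of hydrogen-bond donors and acceptors and the net charge stay the same, and no measurement on hand accounts for the shift.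

The compounds shown leave open whether furan-2-yl lowers the number to a similar extent when the amide nitrogen carries 2-hydroxyethyl or 4-methyl-1,3-thiazol-2-yl instead of 2-fluorophenyl. They also leave open how the read-out would respond at this place to other rings, such as thiophen-2-yl or plain phenyl, or to a ring bearing an amine or a carboxylic acid.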